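Removing the benzamido group from compound 1

The compounds below may be only part of what the source reports. "The series", "measured", "known", "first", "only" and "open" are said of these compounds alone.

- compound 1 `O=C(NC1CCC(CN2CCN(c3cc(=O)c4cc(C(F)(F)F)cc([N+](=O)[O-])c4s3)CC2)CC1)c1ccccc1` gives 90.6%
- compound 2 `O=C(OC1CCC(CN2CCN(c3cc(=O)c4cc(C(F)(F)F)cc([N+](=O)[O-])c4s3)CC2)CC1)c1ccc(C(F)(F)F)cc1` gives 28.8%

In an ADME assay on cells (Hepatocyte, Mus musculus) for metabolic stability, with a stated time of 30 min (a lower number here means that less of the compound is left, a higher number that more of the compound is left), compound 1 stands highest of the two measured compounds, and compound 2 lies lower, beyond the usual scatter. Compound 3 `O=c1cc(N2CCN(CC3CCCCC3)CC2)sc2c([N+](=O)[O-])cc(C(F)(F)F)cc12` differs from compound 1 by one change, (hydrogen in place of benzamido on a saturated ring carbon), that is, hydrogen in place of benzamido on a saturated ring carbon. Within the data shown here, no step between measured compounds isolates this change, so any expectation remains loose. Compound 1 at 90.6% leaves little room to rise, while compound 2 at 28.8% shows that a number on the shared core can lie far lower. A fall beyond the scatter in this assay is therefore expected, with a number 25.6 percentage points lower from compound 1 to compound 3 (beyond the scatter) as the estimated step. Compound 3 is estimated at 65%, with 40% to 88% as the expected range.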

Compound 3, percent of the compound remaining: 80.6%
The estimate for compound 3 lay 15.6 percentage points below the measured number, within the range that was stated.
By their numbers in this assay, from the lowest: compound 2; then compounds 3 and 1 (each within the scatter of the next).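

Hydrogen in place of benzamido on a saturated ring carbon gives a number 10 percentage points lower from compound 1 to compound 3 (within the scatter) in this assay, and this is the first step that reads this position directly. On the shared core, then, the whole benzamido group, with its six-membered aromatic ring and its amide hydrogen, can go without a change that this assay can separate from the usual scatter. Nothing measured here gives a reason for this outcome.

The compounds shown leave open whether other groups at this place, such as an amine or a carboxylic acid, would also stay within the scatter of compound 1. From the compounds shown here alone, it also remains open whether an acetamido group, which keeps the amide but has no aromatic ring, would do the same.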